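Cyano to methoxy on the aryl ring: compound 3

The source may report more compounds than this note shows. Statements on the series, on what has been measured and on what is new or still open speak of the compounds shown alone.

Of the compounds shown here, two carry a number so far. Compound 1 `C#CC(=O)N1C(c2cccc(F)c2)SC[C@@H]1C(=O)OCC` gives 1700 nM in a functional assay on MV cells (Homo sapiens) for inhibition, read by sulforhodamine B assay; a higher number here means a weaker inhibitor, a lower number a stronger inhibitor. Compound 2 `C#CC(=O)N1C(c2ccc(C#N)cc2)SC[C@@H]1C(=O)OCC` gives 2400 nM in this assay; its number is the higher of the two, yet the gap to compound 1 lies within the scatter, so the pair reads as equivalent. Compound 3 `C#CC(=O)N1C(c2ccc(OC)cc2)SC[C@@H]1C(=O)OCC` has not yet been measured in this assay. It differs from compound 2 in one place: methoxy in place of cyano on an aromatic carbon, para to a large group. No comparable change between measured compounds exists in the set, so there is no shown step to lean on. The expected step from compound 2 to compound 3 is one that stays within the scatter, a 1.2-fold lower number from compound 2 to compound 3 (0.08 log units; within the scatter), with no clear direction. Compound 3 is therefore estimated at 2000 nM in this assay, with a range of 700 nM to 6000 nM.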

Compound 3, half-maximal inhibitory concentration: 700 nM
The estimate for compound 3 lay 2.9-fold (0.46 log units) above the measured number; low and high end bracket the measured number.
By their numbers in this assay, from the lowest: compound 3; then compounds 1 and 2 (each within the scatter of the next).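

Methoxy in place of cyano on an aromatic carbon, para to a large group, gives a 3.4-fold lower number from compound 2 to compound 3 (0.54 log units; beyond the scatter) in this assay. Going by these compounds alone, this is the first one-place step, and it shows that the number responds to what this position carries: the two groups match in heavy atoms and hydrogen-bond acceptors as counted, yet the step lies beyond the scatter. The data at hand offer no measurement that would explain the step.

Still open, on these data alone, is whether an amine, a hydroxyl or a longer chain such as ethoxy at this same place would move the number further from that of compound 3 . Also open, as far as these compounds go, is whether a carboxylic acid in place of the ethyl ester would keep the number of compound 3 .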